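The source may report more compounds than this note shows. Statements on the series, on what has been measured and on what is new or still open speak of the compounds shown alone.

In a functional assay on THP-1 cells (Homo sapiens) for inhibition, with a stated time of 48 h, tested at 50 uM (a lower number here means less inhibition of growth, a higher number more inhibition of growth at the concentration tested), three compounds have been measured so far. Compound 1 `C=C[C@@](C)(/C=C/c1ccc(O)c(N)c1)CCC=C(C)C` gives 48%, compound 2 `CC1C(C(C)(C)O)CCC1(C)/C=C/c1ccc(O)cc1` gives 93%, and compound 3 `COc1ccccc1/C=C/[C@@](C)(/C=C/c1ccc(O)cc1)CCC=C(C)C` gives 62%. Compound 3 therefore stands second of the three, above compound 1 and below compound 2, with both gaps beyond the scatter. Compound 4 `COc1ccc(/C=C/[C@@](C)(/C=C/c2ccc(O)cc2)CCC=C(C)C)cc1` has the same atoms joined differently: 4-methoxyphenyl in place of 2-methoxyphenyl on a double-bonded chain carbon bound to a double-bonded chain carbon. The 4-methoxyphenyl replaces 2-methoxyphenyl on a double-bonded chain carbon bound to a double-bonded chain carbon. For the measured compounds named here, no measured pair shows the effect of such a change in this assay, so no step beyond the scatter is expected in either direction. The estimated step is small, a number 2 percentage points higher from compound 3 to compound 4 (within the scatter). For compound 4, the expected value is 64%, with an estimated range of 47% to 82%.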

Compound 4, percent growth inhibition at one concentration: 52%
For compound 4 the middle estimate is 12 percentage points above the measured one, within the range that was stated.
By their numbers in this assay, from the lowest: compounds 1, 4 and 3 (each within the scatter of the next, the first and the last beyond it); then compound 2.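

The change to 4-methoxyphenyl in place of 2-methoxyphenyl on a double-bonded chain carbon bound to a double-bonded chain carbon gives a number 10 percentage points lower from compound 3 to compound 4 (within the scatter) in this assay. This first pair at this place shows that the two methoxyphenyl groups cannot be told apart in this read-out. Nothing available explains the values of these two compounds.

As far as these compounds go, it remains open whether an amine or a carboxylic acid on the phenyl ring at this place would shift growth inhibition beyond the scatter. From the compounds shown here alone, it is also open whether the two methoxyphenyl groups would stay this close at other concentrations.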